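The compounds below may be only part of what the source reports. "The series", "measured", "known", "first", "only" and "open" are said of these compounds alone.

Series so far in a functional assay on HeLa cells (Homo sapiens) for antiproliferative activity, read by MTT assay, with a stated time of 72 h; on this read-out lower numbers stand for stronger inhibition and higher numbers for weaker inhibition:
- Compound 1 `COc1ncc(-c2ccc3c(c2)N(c2ccc(F)cc2)C(=O)CO3)cc1NS(=O)(=O)c1ccc(F)cc1`: 10500 nM
- Compound 2 `COc1ncc(-c2ccc3c(c2)N(c2ccccc2)C(=O)CO3)cc1NS(=O)(=O)c1ccc(F)cc1`: 1530 nM

Compound 2 has the lower of the two numbers, at 1530 nM. Compound 3 `COc1ncc(-c2ccc3c(c2)N(C(C)C)C(=O)CO3)cc1NS(=O)(=O)c1ccc(F)cc1` carries isopropyl in place of phenyl on an amide-type nitrogen in a ring. Going by the values given here, only one measured step bears on this change, a 6.9-fold lower number from compound 1 to compound 2 (0.84 log units; beyond the scatter). It was made on the same phenyl group and was modest. Among the compounds with values here, no measured compound lacks an aromatic ring at this nitrogen, so the direction is uncertain, and a modest rise in this assay is expected. The expected step is a 2.0-fold higher number from compound 2 to compound 3 (0.29 log units; within the scatter). For compound 3 the estimated value is 3000 nM, with an expected range of 600 nM to 15000 nM.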

Compound 3, half-maximal inhibitory concentration: 2790 nM
The estimate for compound 3 lay 1.1-fold (0.03 log units) above the measured number, within the range that was stated.
By their numbers in this assay, from the lowest: compounds 2 and 3 (each within the scatter of the next); then compound 1.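

In this assay, isopropyl, which has no ring, stands on the amide-type nitrogen in place of phenyl with a 1.8-fold higher number from compound 2 to compound 3 (0.26 log units; within the scatter), so an aromatic ring at this position is not needed to keep the number of compound 2. Against 4-fluorophenyl, the same isopropyl gives a 3.8-fold lower number from compound 1 to compound 3 (0.58 log units; beyond the scatter), which leaves compound 1 apart from the other two. Nothing at hand explains either step. Open, as far as these compounds go, is whether a longer chain, an amine or a carboxylic acid on this nitrogen would hold the number in this range.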